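Notes on an amide side-chain change in the series

This account rests on a few compounds, and the source may have more. Where it says the series, first, only, none or still open, it means among the compounds named here.

Measured in an ADME assay on L02 cells (Homo sapiens) for cytotoxicity, read by MTT assay, with a stated time of 48 h; on this read-out higher numbers stand for weaker inhibition and lower numbers for stronger inhibition:
compound 1 `CCn1c(C(=O)NCCN(C)C)ccc1C(CC)(CC)c1ccc(OCC(O)C(C)(C)C)c(C)c1`: 2600 nM
compound 2 `CC[C@@H](C)[C@H](NC(=O)c1ccc(C(CC)(CC)c2ccc(OCC(O)C(C)(C)C)c(C)c2)n1CC)C(=O)O`: 1400 nM

Compound 2 stands at 1400 nM, and compound 1 stands at 2600 nM. These two values lie within the scatter of each other, so neither can be ranked as the lower.

Next is compound 3 `CCn1c(C(=O)N(C)CC(=O)O)ccc1C(CC)(CC)c1ccc(OCC(O)C(C)(C)C)c(C)c1`, not yet measured. The structural change is (carboxymethyl)(methyl)amino in place of (1-carboxy-2-methylbutyl)amino on a carbonyl carbon. The entering (carboxymethyl)(methyl)amino keeps the carboxy unit of the leaving (1-carboxy-2-methylbutyl)amino, on the same carbonyl carbon.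

Among the measured compounds shown here, the only measured step that bears on this is a 1.9-fold lower number from compound 1 to compound 2 (0.27 log units; within the scatter). It put 1-carboxy-2-methylbutyl in place of 2-(dimethylamino)ethyl on an amide-type nitrogen, so it covers a change at the same place in the molecule. For the measured compounds named here, no measured step compares two carboxy-bearing groups, which leaves the estimate resting on that single small step and on two values. A slightly higher number is expected in this assay, with no step beyond the scatter. The expected step is a 1.6-fold higher number from compound 2 to compound 3 (0.20 log units; within the scatter). For compound 3 the estimated value is 2200 nM, with an expected range of 900 nM to 6000 nM.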

Compound 3, half-maximal inhibitory concentration: 32600 nM
The estimate for compound 3 lay 15-fold (1.17 log units) below the measured number, and the stated range ends below it.
By their numbers in this assay, from the lowest: compounds 2 and 1 (each within the scatter of the next); then compound 3.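

The side chain on this carbonyl carbon can shift the read-out in this assay beyond the scatter, with a 23-fold higher number from compound 2 to compound 3 (1.37 log units; beyond the scatter) and a 13-fold higher number from compound 1 to compound 3 (1.10 log units; beyond the scatter) as the steps that show it, whereas the earlier pair of compounds stayed within the scatter. Compound 2 and compound 3 both carry a carboxy unit on this side chain and still lie far apart, so a carboxy unit alone does not fix the number here; the change from (1-carboxy-2-methylbutyl)amino to (carboxymethyl)(methyl)amino also removes the 2 defined stereocentres and the branched chain and adds the methyl on nitrogen, and this single step cannot separate these differences. No measured property in hand accounts for the size of the step.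

Still open, as far as these compounds go, is which of these differences carries the step: (carboxymethyl)amino would test the methyl on nitrogen, and a branched amino acid side chain with that same methyl would test the chain. Also open, from the compounds shown here alone, is what the carboxylic acid itself contributes in the small (carboxymethyl)(methyl)amino group, which a methyl ester or a primary amide in its place would address.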